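Removing a Single Fluorine from a Myeloperoxidase Inhibitor

The compounds below may be only part of what the source reports. "The series", "measured", "known", "first", "only" and "open" are said of these compounds alone.

Compound 1 `Nc1cc(Cc2ccn(-c3ccc(F)cc3)n2)c2nn[nH]c2n1`: 53 nM
Compound 2 `Nc1cc(C2CCNCCc3cccc(c3)Oc3cccc(c3)Cn3cc2cn3)c2nn[nH]c2n1`: 14 nM

Both measured compounds were tested in an assay on isolated protein for inhibition of Myeloperoxidase (Homo sapiens), with a stated time of 10 min; a lower number here means a stronger inhibitor, a higher number a weaker inhibitor. Compound 1 gives 53 nM and compound 2 gives 14 nM. Compound 1 thus has the higher of the two numbers, and its gap to compound 2 lies beyond the scatter, so compound 1 is the weaker inhibitor of the pair.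

Compound 3 `Nc1cc(Cc2ccn(-c3ccccc3)n2)c2nn[nH]c2n1` has not yet been measured. It differs from compound 1 in one place only: hydrogen in place of fluoro on an aromatic carbon, in other words hydrogen in place of fluoro on an aromatic carbon of the ring that hangs off the shared core. Among the compounds with values here, no pair of measured compounds shows this same change, so there is no measured step to lean on; the change itself removes one fluorine and nothing more. The expected step of a 1.5-fold higher number from compound 1 to compound 3 (0.18 log units; within the scatter) is small, a slightly higher number that stays within the scatter. Compound 3 is expected to give 80 nM, with a range from 30 nM to 220 nM.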

Compound 3, half-maximal inhibitory concentration: 55 nM
Compound 3: middle estimate off by 1.5-fold (0.16 log units), on the high side; measured number inside the range.
By their numbers in this assay, from the lowest: compound 2; then compounds 1 and 3 (each within the scatter of the next).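

In this assay the change from 4-fluorophenyl to phenyl gives a 1.0-fold higher number from compound 1 to compound 3 (0.02 log units; within the scatter) and so the two compounds cannot be told apart. At this place on the six-membered aromatic ring, para to a large group, hydrogen serves as well as fluoro in this pair, so the fluorine is not needed to keep the inhibition seen with compound 1. Nothing available explains this result.

What the compounds shown leave open is whether a bulkier or more elaborate group at the same place, such as a methoxy group, an amine or a carboxylic acid, would keep the inhibition or shift it clearly. They also leave open whether fluoro and hydrogen would match each other at other places on this ring.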